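Sulfonamide chain lengthening on two cores

The source may hold more compounds than are shown below. What is called first, only, known or untested is meant among the compounds shown, and "the series" means these compounds.

Measured compounds:
compound 1 `CCCNS(=O)(=O)c1ccc(Nc2ncc3c(n2)N(c2ccn(C)n2)C(CC)C(=O)N3C)cc1`: 2670 nM
compound 2 `CCCCNS(=O)(=O)c1ccc(Nc2ncc3c(n2)N(C2CCCC2)[C@H](CC)C(=O)N3C)cc1`: 451 nM
compound 3 `CCCNS(=O)(=O)c1ccc(Nc2ncc3c(n2)N(C2CCCC2)[C@H](CC)C(=O)N3C)cc1`: 459 nM

In a functional assay on HeLa cells (Homo sapiens) for antiproliferative activity, read by CCK-8 assay, with a stated time of 72 h (a lower number here means a stronger inhibitor of growth, a higher number a weaker inhibitor of growth), compound 1 gives 2670 nM, compound 3 gives 459 nM and compound 2 gives 451 nM. Compound 1 is the weakest of the three, beyond the scatter from both others. The difference between the core of compound 1 and the core of compound 3 is not broken down here.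

Compound 2 differs from compound 3 by methyl in place of hydrogen on a saturated chain carbon, three bonds along the chain from a sulfonamide nitrogen, and this made a 1.0-fold lower number from compound 3 to compound 2 (0.01 log units; within the scatter).

Compound 4 `CCCCNS(=O)(=O)c1ccc(Nc2ncc3c(n2)N(c2ccn(C)n2)C(CC)C(=O)N3C)cc1` carries the same change on the core of compound 1: methyl in place of hydrogen on a saturated chain carbon, three bonds along the chain from a sulfonamide nitrogen. For compound 4 the expected step is a 1.0-fold higher number from compound 1 to compound 4 (0.00 log units; within the scatter), because a 1.0-fold lower number from compound 3 to compound 2 (0.01 log units; within the scatter) lay within the scatter on the other core. Compound 4 is therefore estimated at 2700 nM in this assay, between 1300 nM and 5600 nM.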

Compound 4, concentration for 50% growth inhibition: 4320 nM
For compound 4 the middle estimate is 1.6-fold (0.20 log units) below the measured one, and the stated range covers the measured number.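

In this assay the propyl to butyl change gives a 1.6-fold higher number from compound 1 to compound 4 (0.21 log units; within the scatter), so on the core of compound 1 it also stays inside the scatter. The two cores do not differ measurably in their response to this change: the same change on two cores in this assay, a 1.0-fold lower number (0.01 log units; within the scatter) from compound 3 to compound 2 and a 1.6-fold higher number (0.21 log units; within the scatter) from compound 1 to compound 4, 1.6-fold (0.22 log units) apart, within the scatter of two such steps.
For the compounds shown here, this supports carrying this one change between these two cores in this assay, but it is a comparison of only two pairs and does not show that the change would be without effect on any other core.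

On these data alone, whether a longer chain than butyl, or an amine or a carboxylic acid at the chain end, would keep the number flat stays open. Which part of the difference between the core of compound 1 and the core of compound 3 sets their gap also stays open.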